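The compounds below may be only part of what the source reports. "The series", "measured", "known", "first", "only" and "open" are said of these compounds alone.

Compound 3 `CCO[C@H]1C[C@@H](c2coc3ccccc3c2=O)N(c2ccccc2)O1` was examined in a functional assay on A549 cells (Homo sapiens) for inhibition, read by sulforhodamine B assay, with a stated time of 48 h; a higher number here means a weaker inhibitor, a lower number a stronger inhibitor. In this assay compound 3 gives > 60000 nM, which is a limit of the assay rather than a number. Compound 1 `O=c1c([C@@H]2C[C@H](c3ccccc3)ON2c2ccccc2)coc2ccccc12` gives > 60000 nM, again a limit. Compound 2 `NC(=O)[C@H]1C[C@@H](c2coc3ccccc3c2=O)N(c2ccccc2)O1` gives > 60000 nM, also a limit. Compound 3 thus stands at the same limit as the other two, namely (the limit of > 60000 nM in this assay, at which 3 of the 3 values shown sit). Compound 4 `COC(=O)[C@H]1C[C@@H](c2coc3ccccc3c2=O)N(c2ccccc2)O1` differs from compound 3 by methoxycarbonyl in place of ethoxy on a saturated ring carbon. The steps bearing on this change, a step that the two limits leave unreadable from compound 1 to compound 2, a step that the two limits leave unreadable from compound 1 to compound 3 and a step that the two limits leave unreadable from compound 2 to compound 3, start and end at limits and give no readable size. No step beyond the scatter is therefore expected in this assay for compound 4, and another limit is the most likely outcome. Compound 4 is estimated at 80000 nM, between 40000 nM and 200000 nM. This corresponds to an expected step that the limit leaves unreadable from compound 3 to compound 4.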

Compound 4, half-maximal inhibitory concentration: > 60000 nM
Compound 4: only a limit was reported; the forecaster's own chance of this, stated with the estimate: 85%; the middle value is on the limit's open side.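

In this assay compound 4 gives > 60000 nM, which is a limit, and its steps from compound 1, compound 2 and compound 3 cannot be read. The compounds shown leave open whether any group on the saturated ring carbon gives a measurable value.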